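A few compounds are considered here, and "the series" means these few. Any claim that something is new, unique, unknown or untested is made for them only; others in the source may bear on it.

Measured so far in a functional assay on the whole organism for antagonist activity, with Mus musculus as the target; on this read-out higher numbers stand for an effect only at larger amounts of compound and lower numbers for an effect already at smaller amounts:
compound 1 `COc1cc(N)c(Cl)cc1NC(=O)C1CCN(CC2CCCCC2)CC1` gives 2.9 mg/kg
compound 2 `COc1cc(N)c(Cl)cc1NC(=O)C1CCN(CC2CCCCCC2)CC1` sits at a limit of this assay, > 10 mg/kg
compound 3 `COc1cc(N)c(Cl)cc1NC(=O)C1CCN(Cc2cccc(C)c2)CC1` gives 2.4 mg/kg

Compound 1 holds the higher of the two numbers in this assay; compound 3 is nearest, and that gap lies within the scatter. Compound 4 `COc1cccc(CN2CCC(C(=O)Nc3cc(Cl)c(N)cc3OC)CC2)c1` is not yet measured. It differs from compound 1 by 3-methoxyphenyl in place of cyclohexyl on a saturated chain carbon bound to an amine nitrogen in a ring. Going by the values given here, two measured steps bear on this change. Replacing the same cyclohexyl by an aromatic ring gave a 1.2-fold lower number from compound 1 to compound 3 (0.08 log units; within the scatter), within the scatter. Enlarging the saturated ring gave an at least 3.4-fold higher number from compound 1 to compound 2 (0.53 log units; beyond the scatter), beyond it, though only as a limit (the limit of > 10 mg/kg in this assay, at which 1 of the 3 values shown sits). An aromatic replacement is therefore expected to move this assay by no more than the scatter: for compound 4 the estimate is 2.7 mg/kg, range 1.2 mg/kg to 6.5 mg/kg, meaning an expected step of a 1.1-fold lower number from compound 1 to compound 4 (0.03 log units; within the scatter).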

Compound 4, dose for half-maximal effect: > 4 mg/kg
Compound 4 ended at the assay's limit (the forecaster's own chance of this, stated with the estimate: 15%); middle value at least 1.4-fold (0.17 log units) away from the limit.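

In this assay compound 4 stands at a limit, > 4 mg/kg, and this is not a number. Methoxy in place of methyl on the aromatic carbon is the first change on the aromatic ring itself, and the floors read an at least 1.3-fold higher number from compound 1 to compound 4 (0.13 log units; that floor lies within the scatter) and an at least 1.6-fold higher number from compound 3 to compound 4 (0.22 log units; that floor lies within the scatter), so a real loss at this position is possible but not established. The step between compound 2 and compound 4 cannot be read. Still open, on these data alone, is where compound 4 truly lies, and how an amine or a carboxylic acid in place of methoxy on the aromatic carbon would read.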